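The source may hold more compounds than are shown below. What is called first, only, known or untested is meant among the compounds shown, and "the series" means these compounds.

Measured compounds in the series:
compound 1 `O=C1OC2(CCN(Cc3ccccc3)CC2)c2csc(-c3ccccc3)c21`: 11 nM
compound 2 `O=C1OC2(CCN(Cc3ccccc3)CC2)c2c1csc2-c1ccccc1`: 483 nM
compound 3 `N#Cc1ccc(-c2scc3c2C(=O)OC32CCN(Cc3ccccc3)CC2)cc1`: 6.3 nM

All numbers come from an assay on membranes from brain for displacement of a labelled ligand from Sigma non-opioid intracellular receptor 1 (Cavia porcellus), read by scintillation counting, with a stated time of 120 min; a lower number here means a stronger inhibitor, a higher number a weaker inhibitor. In this assay compound 1 gives 11 nM and compound 3 gives 6.3 nM. Compound 3 differs from compound 1 by cyano in place of hydrogen on an aromatic carbon. That change made a 1.7-fold lower number from compound 1 to compound 3 (0.24 log units; within the scatter).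

Compound 2 gives 483 nM in this assay, the highest number of the three. Its core and the core of compound 1 hold the same atoms joined differently; the difference between the two cores is not broken down here.

Compound 4 `N#Cc1ccc(-c2scc3c2C2(CCN(Cc4ccccc4)CC2)OC3=O)cc1` has not yet been measured in this assay. It differs from compound 2 by cyano in place of hydrogen on an aromatic carbon, and the place of the change reads the same as for compound 1 to compound 3, so this is the same change on the other core.

Among the compounds with values here, the step on the core of compound 2 is expected to be a 1.6-fold lower number from compound 2 to compound 4 (0.21 log units; within the scatter), resting on the single earlier instance, a 1.7-fold lower number from compound 1 to compound 3 (0.24 log units; within the scatter), which lay within the scatter. Compound 4 is therefore estimated at about 300 nM in this assay, with the expected range running from 120 nM to 900 nM.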

Compound 4, inhibition constant: 190 nM
For compound 4 the middle estimate is 1.6-fold (0.20 log units) above the measured one, within the range that was stated.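

On the core of compound 2, the change from phenyl to 4-cyanophenyl gives in this assay a 2.5-fold lower number from compound 2 to compound 4 (0.41 log units; beyond the scatter), a modest step. Set beside the step on the core of compound 1, it shows no detectable difference between the two cores, so the change carries across them with about the same size: the same change on two cores in this assay, a 1.7-fold lower number (0.24 log units; within the scatter) from compound 1 to compound 3 and a 2.5-fold lower number (0.41 log units; beyond the scatter) from compound 2 to compound 4, 1.5-fold (0.16 log units) apart, within the scatter of two such steps. Within the data shown here, this is one pair on each core and only the step on the core of compound 2 lies beyond the scatter, so it sets no rule for other cores, gives no cause for either step, and does not bring the two cores together, with compound 4 at 190 nM and compound 3 at 6.3 nM.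

Cyano is the only substituent shown on this phenyl ring, so it remains open whether a trifluoromethyl, an amine or a carboxylic acid in its place would also move the number alike on both cores. Also open, from the compounds shown here alone, is whether such a match would hold for a change elsewhere, such as a longer chain in place of the benzyl group.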